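Ring-closed carboxylate in place of an open amino acid tail

The source may hold more compounds than are shown below. What is called first, only, known or untested is meant among the compounds shown, and "the series" means these compounds.

Measured so far:
compound 1, `COc1ccc(/C=C\c2cc(OC)c(OC)c(OC)c2)cc1OCc1ccc(CN[C@H](C(=O)O)[C@H](C)O)cc1`: in a functional assay on B16-F10 cells (Mus musculus) for antiproliferative activity, read by CCK-8 assay, with a stated time of 48 h (on this read-out lower numbers stand for stronger inhibition and higher numbers for weaker inhibition), compound 1 gives > 10000 nM
compound 2, `COc1ccc(/C=C\c2cc(OC)c(OC)c(OC)c2)cc1OCc1ccc(CN2CCCCC2C(=O)NCCNC(=O)OC(C)(C)C)cc1`: in this assay compound 2 gives 4700 nM

The value for compound 1 is a limit of the assay rather than a number, since it sits at the limit of > 10000 nM in this assay, at which 1 of the 2 values shown sits. Compound 1 therefore stands at the weak end of the two results shown, with no exact figure of its own. Compound 2 gives a measured number inside the range of this assay. Going by the values given here, the two compounds differ in more than one place, so no single step between them is counted here; their values show only that compound 2 reaches a measurable number where compound 1 does not.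

Compound 3, `COc1ccc(/C=C\c2cc(OC)c(OC)c(OC)c2)cc1OCc1ccc(CN2CC[C@@H](C(=O)O)C2)cc1`, is not yet measured. It differs from compound 1 in one place: 3-carboxypyrrolidin-1-yl in place of (1-carboxy-2-hydroxypropyl)amino on a saturated chain carbon bound to an aromatic carbon. The group that enters keeps a carboxylic acid but carries it on a five-membered ring, and the hydroxyl of the open chain is gone. Among the compounds with values here, no measured step tells how this change reads in this assay, so the expectation rests on the two values shown. Compound 3 is expected to give 8000 nM, with a range from 2500 nM to 25000 nM. The expected step of an at least 1.2-fold lower number from compound 1 to compound 3 (0.09 log units; that floor lies within the scatter) is small, toward stronger inhibition, and may not exceed the usual scatter; a limit again is possible.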

Compound 3, half-maximal inhibitory concentration: > 10000 nM
Compound 3 was reported as a limit; the forecaster's own chance of this, stated with the estimate: 40%; middle value at least 1.2-fold (0.09 log units) from the limit.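

In this assay compound 3 gives > 10000 nM as a limit of the assay, not a number. Going by these compounds alone, compound 1 sits at a limit too, so no step from compound 1 to compound 3 can be read. As far as these compounds go, it stays open whether 3-carboxypyrrolidin-1-yl or (1-carboxy-2-hydroxypropyl)amino gives the stronger inhibition, and by how much.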